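This account rests on a few compounds, and the source may have more. Where it says the series, first, only, none or still open, it means among the compounds named here.

Measured compounds:
compound 1, `CCCCCCN(CCCCCC)S(=O)(=O)NC(=O)Oc1c(C(C)(C)C)cc(C)cc1C(C)(C)C`: 4300 nM
compound 2, `COc1cc(C(C)C)c(OC(=O)NS(=O)(=O)Oc2c(C(C)C)cccc2C(C)C)c(C(C)C)c1`: > 25000 nM

In an assay on liver for inhibition of sterol O-acyltransferase 1 (Rattus norvegicus), using microsomes (on this read-out higher numbers stand for weaker inhibition and lower numbers for stronger inhibition), compound 1 gives 4300 nM. Compound 2 does not give a number in this assay; its result is a limit, > 25000 nM. Among the two results shown, compound 2 therefore stands at the limit of > 25000 nM in this assay, at which 1 of the 2 values shown sits. Among the compounds with values here, no single-change step between the two measured compounds is available, since they differ in several places at once, so only their two values can be set side by side.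

Compound 3, `CC(=O)c1cc(C(C)C)c(OC(=O)NS(=O)(=O)Oc2c(C(C)C)cccc2C(C)C)c(C(C)C)c1`, is not yet measured in this assay. It differs from compound 2 in one place: acetyl in place of methoxy on an aromatic carbon. The rest of compound 2 is kept. Within the data shown here, with compound 2 known only as a limit in this assay, no measured step exists from which the direction or size of this change could be read. The expectation is that the step of a number no higher from compound 2 to compound 3 (the limit leaves the size open) stays within the usual scatter, so that compound 3 most likely again comes out as a limit rather than a number. Compound 3 is estimated at 25000 nM in this assay, within the range 8000 nM to 80000 nM.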

Compound 3, half-maximal inhibitory concentration: 41800 nM
For compound 3 the middle estimate is 1.7-fold (0.22 log units) below the measured one, and the stated range covers the measured number.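

In this assay, within the data shown here, compound 2 gives > 25000 nM, which is a limit and not a number, so no step from compound 2 to compound 3 can be read. The compounds shown leave open whether acetyl in place of methoxy on an aromatic carbon strengthens or weakens inhibition, and by how much.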